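Thiocarbonyl Amine Swap on a Benzamide Series

The source may hold more compounds than are shown below. What is called first, only, known or untested is meant among the compounds shown, and "the series" means these compounds.

Compound 1 `Nc1ccccc1NC(=O)c1ccc(CSC(=S)N2CCc3cc(Cl)ccc32)cc1` is the anchor of this account. In a functional assay on HeLa cells (Homo sapiens) for antiproliferative activity, read by CCK-8 assay, with a stated time of 72 h, tested at 2 uM (a higher number here means a stronger effect of the compound at the concentration tested, a lower number a weaker effect), compound 1 gives 40.1%, the second highest of the three numbers on hand. Compound 3 `Nc1ccccc1NC(=O)c1ccc(CSC(=S)N2CCN(c3ncccn3)CC2)cc1` stands nearest to it, and in this assay compound 3 gives 52.2%, a result beyond the usual scatter above that of compound 1. Compound 2 `Nc1ccccc1NC(=O)c1ccc(CSC(=S)N(Cc2ccccc2)Cc2ccccc2)cc1` lies furthest away; in this assay compound 2 gives 1%, far below compound 1 and again beyond the scatter.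

Compound 4 `CN(Cc1cccnc1)C(=S)SCc1ccc(C(=O)Nc2ccccc2N)cc1` has not yet been measured in this assay. It departs from compound 1 at one place only: methyl((pyridin-3-yl)methyl)amino in place of 5-chloro-2,3-dihydro-1H-indol-1-yl on a thiocarbonyl carbon. The ring-fused amine on the thiocarbonyl carbon is thus replaced by a smaller amine carrying a pyridine, while the shared core is kept intact.

Among the compounds with values here, with no measured pair of this kind to lean on, the step is expected to be downward and beyond the scatter, and the expected step of a number 15.1 percentage points lower from compound 1 to compound 4 (beyond the scatter) reflects that. Compound 4 is expected to reach 25%, within a range from 5% to 50%, a position between the values shown by compound 2 and compound 1.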

Compound 4, a percentage reported as inhibition, at one concentration (the size of the read-out at that concentration, not a potency): 16.4%
Compound 4: middle estimate off by 8.6 percentage points, on the high side, within the range that was stated.
By their numbers in this assay, from the lowest: compound 2; then compound 4; then compound 1; then compound 3.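

Within the data shown here, the swap on a thiocarbonyl carbon whose other neighbours are sulfur gives the first single-change comparison at this position: in this assay, the read-out shows a number 23.7 percentage points lower from compound 1 to compound 4 (beyond the scatter). Replacing 5-chloro-2,3-dihydro-1H-indol-1-yl with methyl((pyridin-3-yl)methyl)amino, while the shared core stays intact, is thus enough by itself to shift the inhibition, and the entering pyridine-bearing amine does not hold the level of compound 1. No independent evidence on hand bears on what lies behind this shift.

The change removes the chlorine, removes the fused ring and brings in the pyridine nitrogen all at once, and the compounds shown do not separate these parts. A 2,3-dihydro-1H-indol-1-yl group without the chlorine, or a benzyl(methyl)amino group in the same place, would be needed to tell them apart.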